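Naphthalen-2-yl for nitrophenyl: estimating compound 4

The compounds below may be only part of what the source reports. "The series", "measured", "known", "first", "only" and "open" are said of these compounds alone.

Measured in a functional assay on 1321-N1 cells for agonist activity at P2Y purinoceptor 6 (Homo sapiens), read by scintillation counting and inositol phosphate accumulation; on this read-out lower numbers stand for an effect already at smaller amounts and higher numbers for an effect only at larger amounts of compound:
- compound 1, `O=c1[nH]/c(=N\OCCCCc2ccccc2)ccn1[C@@H]1O[C@H](COP(=O)(O)OP(=O)(O)OP(=O)(O)O)[C@@H](O)[C@H]1O`, gives 251 nM
- compound 2, `O=c1[nH]/c(=N\OCCCc2cccc(F)c2)ccn1[C@@H]1O[C@H](COP(=O)(O)OP(=O)(O)OP(=O)(O)O)[C@@H](O)[C@H]1O`, gives 539 nM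
- compound 3, `O=c1[nH]/c(=N\OCCCc2ccc([N+](=O)[O-])cc2)ccn1[C@@H]1O[C@H](COP(=O)(O)OP(=O)(O)OP(=O)(O)O)[C@@H](O)[C@H]1O`, gives 1330 nM

Compound 3 stands at the highest number of the three, so it needs the largest amount of compound to produce its effect; the nearest is compound 2 and the furthest compound 1.

Compound 4 is `O=c1[nH]/c(=N\OCCCc2ccc3ccccc3c2)ccn1[C@@H]1O[C@H](COP(=O)(O)OP(=O)(O)OP(=O)(O)O)[C@@H](O)[C@H]1O`. The change from compound 3 is naphthalen-2-yl in place of 4-nitrophenyl on a saturated chain carbon, three bonds along the chain from an oxygen.

Within the data shown here, two measured steps bear on this, since both also swap the group at that same place. Going from a group with no acceptors to 4-nitrophenyl gave a 5.3-fold higher number from compound 1 to compound 3 (0.72 log units; beyond the scatter), and from 3-fluorophenyl to 4-nitrophenyl gave a 2.5-fold higher number from compound 2 to compound 3 (0.39 log units; beyond the scatter). Compound 4 moves the other way, from 4-nitrophenyl back to a group without acceptors, so a lower number is expected, probably of a size between those two steps.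

For compound 4 the expected step is a 3.8-fold lower number from compound 3 to compound 4 (0.58 log units; beyond the scatter), giving an estimate of 350 nM, within 120 nM to 1000 nM.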

Compound 4, half-maximal effective concentration: 90 nM
Estimate against measurement, compound 4: 3.9-fold (0.59 log units) above, and the stated range ends above it.
By their numbers in this assay, from the lowest: compound 4; then compound 1; then compound 2; then compound 3.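

Naphthalen-2-yl is the first group at this place, on a saturated chain carbon, three bonds along the chain from an oxygen, to bring the number below that of compound 1 in this assay, with a 2.8-fold lower number from compound 1 to compound 4 (0.45 log units; beyond the scatter). The same change also gives a 6.0-fold lower number from compound 2 to compound 4 (0.78 log units; beyond the scatter) and a 15-fold lower number from compound 3 to compound 4 (1.17 log units; beyond the scatter), so a carbon-only group with 2 six-membered aromatic rings is not merely accepted here but gives the lowest number of the four compounds. Nothing measured here explains why this group does so well.

On these data alone, it remains open whether the gain belongs to naphthalen-2-yl in particular or would also appear with naphthalen-1-yl. Also unresolved is how a longer chain ending in naphthalen-2-yl, or an amine or carboxylic acid placed on that group, would shift the number.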